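The source may hold more compounds than are shown below. What is called first, only, known or untested is meant among the compounds shown, and "the series" means these compounds.

Compound 2 `COc1cccc(NC(=O)NC2CC(C)(C)Oc3ccc(Cl)cc32)c1` carries a chloro group on the shared core and a urea that joins it to a methoxy-bearing aryl ring. In a functional assay (aorta) with Rattus norvegicus as the target (a lower number here means that less compound is needed, a higher number that more compound is needed for the effect), compound 2 gives > 10000 nM, which is a limit of the assay and not a number. Its relative compound 1 `COc1ccccc1NC(=O)NC1CC(C)(C)Oc2ccc(Br)cc21` differs in the halogen and in the arrangement of the methoxy-bearing aryl ring. In this assay compound 1 gives > 10000 nM, again a limit rather than a number. Both results sit at the limit of > 10000 nM in this assay, at which 2 of the 2 values shown sit, so compound 2 cannot be ordered against compound 1: the two are indistinguishable at that limit. Compound 3 `COc1cccc(NC(=O)NC2CC(C)(C)Oc3ccc(Br)cc32)c1` is the bromo analogue of compound 2, differing by bromo in place of chloro on an aromatic carbon. Among the measured compounds shown here, no measured pair differing only in this way exists here, so the size of such a step is unknown from the data. Compound 1, which itself carries bromo, gives only > 10000 nM in this assay. Compound 3 is therefore expected to come out near 15000 nM, within a range from 5000 nM to 50000 nM. The step from compound 2 to compound 3 is estimated at a step that the limit leaves unreadable from compound 2 to compound 3, none beyond the scatter.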

Compound 3, half-maximal effective concentration: > 10000 nM
Compound 3 gave a limit, no number; the forecaster's own chance of this, stated with the estimate: 85%; the middle value does not contradict the limit.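

In this assay compound 3 gives > 10000 nM as a limit of the assay and not a number. The steps to compound 3 from compound 2 and from compound 1 therefore cannot be read: the limit of > 10000 nM in this assay, at which 3 of the 3 values shown sit. The compounds shown leave open whether bromo in place of chloro, or 3-methoxyphenyl in place of 2-methoxyphenyl, changes the result in this assay at all.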